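The source may report more compounds than this note shows. Statements on the series, on what has been measured and on what is new or still open speak of the compounds shown alone.

Measured values in a functional assay on cells (T-cell, Mus musculus, strain BALB/c) for inhibition, read by MTT assay, with stated times of 24 h and 72 h; a higher number here means a weaker inhibitor, a lower number a stronger inhibitor:

- compound 1 `COc1cc(-c2nnc(SCc3ccc([N+](=O)[O-])cc3)o2)ccc1O` gives 14200 nM
- compound 2 `COc1cc(-c2nnc(SCc3ccc(C)cc3)o2)ccc1O` gives 6210 nM
- compound 3 `COc1cc(-c2nnc(SCc3cccc([N+](=O)[O-])c3)o2)ccc1O` gives 16000 nM

Compound 2 holds the lowest number of the three. Among the compounds with values here, the nearest neighbour is compound 1, the only step recorded against it: a 2.3-fold lower number from compound 1 to compound 2 (0.36 log units; beyond the scatter). Compound 3 lies further off, its value of 16000 nM sitting beyond the scatter from compound 2 in the same direction, so on the numbers shown compound 2 is the strongest inhibitor of the set.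

The next compound, compound 4 `COc1cc(-c2nnc(SCc3ccccc3F)o2)ccc1O`, departs from compound 2 in one place: 2-fluorophenyl in place of 4-methylphenyl on a saturated chain carbon bound to a sulfur.

Within the data shown here, only one measured step touches this change, and only loosely. The step of a 2.3-fold lower number from compound 1 to compound 2 (0.36 log units; beyond the scatter) shows that the group on that aromatic ring moves the number by a modest amount, with methyl giving the lower figure. Among the measured compounds shown here, no measured pair swaps methyl for fluorine, and no measured pair moves a group to the position that 2-fluorophenyl carries, so the direction for compound 4 is not fixed by the data. The most that can be read is that a small group on this ring has so far mattered within a modest span.

For compound 4 the number is therefore expected near that of compound 2, at 8000 nM with a range of 3500 nM to 18000 nM. The implied step a 1.3-fold higher number from compound 2 to compound 4 (0.11 log units; within the scatter) is expected to stay within the scatter.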

Compound 4, half-maximal inhibitory concentration: 5790 nM
The estimate for compound 4 lay 1.4-fold (0.14 log units) above the measured number, and the stated range covers the measured number.
By their numbers in this assay, from the lowest: compounds 4 and 2 (each within the scatter of the next); then compounds 1 and 3 (each within the scatter of the next).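

In this assay, 2-fluorophenyl in place of 4-methylphenyl on a saturated chain carbon bound to a sulfur gives a 1.1-fold lower number from compound 2 to compound 4 (0.03 log units; within the scatter), so the two groups cannot be told apart at this position. Within the data shown here, until now the only single-place step on this ring was the exchange of nitro for methyl, and it left open whether methyl was the one group giving a number as low as that of compound 2; compound 4 shows that 2-fluorophenyl, which carries no methyl, does the same within the scatter. No measurement at hand accounts for this match, and the series offers no explanation of it.

The compounds shown leave open how far this position can be changed before the number moves, as every ring here is a six-membered aromatic ring of carbon only, carrying one small group, and a ring bearing an amine or a carboxylic acid would test a much wider change. Also open, from the compounds shown here alone, is the link itself: a longer chain between the sulfur and the ring, and any change to the shared core, remain unaddressed in this set.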